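Replacing a Ring-Closed Side Chain with an Open Diol

The compounds below may be only part of what the source reports. "The series", "measured", "known", "first", "only" and "open" are said of these compounds alone.

Compound 2 `C=CC(C)(C)c1[nH]c2ccc(C[C@H]3OC(C)(C)OC3(C)C)cc2c1/C=C1\NC(=O)[C@H](C)NC1=O` and compound 1 `C=CC(C)(C)c1[nH]c2ccc(C[C@@H](O)C(C)(C)Cl)cc2c1/C=C1\NC(=O)[C@H](C)NC1=O` share one core and differ only in the group on a saturated chain carbon bound to an aromatic carbon. In a functional assay (a lower number here means a stronger inhibitor, a higher number a weaker inhibitor), compound 2 gives 88000 nM, the larger of the two numbers recorded so far, while compound 1 gives 79000 nM; the gap between them, a 1.1-fold higher number from compound 1 to compound 2 (0.05 log units; within the scatter), is within the scatter, so neither can be called the weaker or the stronger inhibitor. Compound 3 `C=CC(C)(C)c1[nH]c2ccc(C[C@@H](O)C(C)(C)O)cc2c1/C=C1\NC(=O)[C@H](C)NC1=O` carries 1,2-dihydroxy-2-methylpropyl in place of 2,2,5,5-tetramethyl-1,3-dioxolan-4-yl on a saturated chain carbon bound to an aromatic carbon. For the measured compounds named here, the only measured step touching this position is a 1.1-fold higher number from compound 1 to compound 2 (0.05 log units; within the scatter), which exchanged one side chain for another at the same place and left the number essentially unmoved. Nothing else among the measured compounds speaks to the change. On that basis compound 3 is expected to show a step of a 1.1-fold lower number from compound 2 to compound 3 (0.04 log units; within the scatter) in this assay, that is, no movement beyond the scatter. Compound 3 is therefore estimated at 80000 nM, with a likely range from 30000 nM to 200000 nM.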

Compound 3, half-maximal inhibitory concentration: 79000 nM
Compound 3: middle estimate off by 1.0-fold (0.01 log units), on the high side; low and high end bracket the measured number.
By their numbers in this assay, from the lowest: compounds 1, 3 and 2 (each within the scatter of the next).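

In this assay the ring of 2,2,5,5-tetramethyl-1,3-dioxolan-4-yl can be replaced by the open 1,2-dihydroxy-2-methylpropyl chain (a 1.1-fold lower number from compound 2 to compound 3 (0.05 log units; within the scatter)), so at this place, on a saturated chain carbon bound to an aromatic carbon, the read-out does not separate a ring with 0 hydrogen-bond donors from an open chain with 2. The new pair also isolates a single atom exchange that the earlier step could not. That step replaced the whole side chain, while this one is hydroxy in place of chloro on a saturated chain carbon bound to three saturated chain carbons (no change at the digits printed from compound 1 to compound 3 (within the scatter)). All three side chains therefore lie within the scatter of one another, and none can be ranked above another.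

Whether any group at this place can move the number beyond the scatter stays open, since an amine, a carboxylic acid and a longer chain are not among the compounds shown. No accompanying measurement says why these three side chains read alike.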